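From Propyl to Isobutyl: A Small Change Tested

The source may hold more compounds than are shown below. What is called first, only, known or untested is meant among the compounds shown, and "the series" means these compounds.

Compound 1, `COc1ccc(OC(=O)Nc2ccc([Se]C#N)cc2)cc1`: 70000 nM
Compound 2, `CCCOC(=O)Nc1ccc([Se]C#N)cc1`: 68800 nM
Compound 3, `CCOC(=O)Nc1ccc([Se][Se]c2ccc(NC(=O)OCC)cc2)cc1`: 74300 nM

Of the compounds shown here, three have been measured in a functional assay on CCRF-CEM cells (Homo sapiens) for cytotoxicity, read by MTT assay, with a stated time of 72 h; a higher number here means that more compound is tolerated, a lower number that less compound is tolerated. In this assay compound 1 gives 70000 nM, compound 2 gives 68800 nM, and compound 3 gives 74300 nM. The three numbers sit so close together that compound 2 cannot be set apart from compound 1 or from compound 3: each gap to it falls inside the usual scatter of repeated measurements, so the three read as one level rather than as a sequence.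

A fourth compound, compound 4, `CC(C)COC(=O)Nc1ccc([Se]C#N)cc1`, has not yet been measured. It differs from compound 2 in a single place: methyl in place of hydrogen on a saturated chain carbon bound to two saturated chain carbons. In other words, the propyl group of compound 2 becomes an isobutyl group in compound 4, and nothing else changes.

Among the measured compounds shown here, since no measured pair in this set shows what such a change does, there is no step to lean on. The three measured compounds, which differ in larger ways than this, all land at the same level, so no movement beyond the scatter is expected in this assay for compound 4. The estimate for compound 4 is therefore 68800 nM, with a range from 34000 nM to 140000 nM. This estimate means an expected step of no change at the digits printed from compound 2 to compound 4 (within the scatter) that stays within the scatter.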

Compound 4, concentration lethal to 50% of the cells: 68700 nM
For compound 4 the middle estimate is 1.0-fold (0.00 log units) above the measured one; the range from low to high includes it.
By their numbers in this assay, from the lowest: compounds 4, 2, 1 and 3 (each within the scatter of the next).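

Methyl in place of hydrogen on a saturated chain carbon bound to two saturated chain carbons, the change that makes an isobutyl group from a propyl group, gives a 1.0-fold lower number from compound 2 to compound 4 (0.00 log units; within the scatter) in this assay and is the first change in this set that can be read in a single place. The earlier compounds shown here differ from one another in larger ways, so their shared level could only hint at what this one position allows, whereas this pair shows directly that the added branch leaves the number inside the scatter and that the assay does not tell these two chains apart. Nothing measured alongside these compounds offers an explanation for this result.

On these data alone, a single added methyl is a small probe, so it remains open whether a much longer chain, an amine or a carboxylic acid at this place would stay at the same level or move beyond the scatter. The compounds shown also leave open whether compound 2 and compound 4 would still read alike on other kinds of cells or after a different exposure time.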